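From 2-chlorophenyl to 3-methylphenyl on a shared core

A few compounds are considered here, and "the series" means these few. Any claim that something is new, unique, unknown or untested is made for them only; others in the source may bear on it.

- compound 1 `O=C1C=C(N2CCN(c3ccccc3)CC2)C(=O)c2ccccc21` gives 9900 nM
- compound 2 `O=C1C=C(N2CCN(c3cccc(Cl)c3)CC2)C(=O)c2ccccc21` gives 8300 nM
- compound 3 `O=C1C=C(N2CCN(c3ccccc3Cl)CC2)C(=O)c2ccccc21` gives 2900 nM

These values come from a functional assay on DU-145 cells (Homo sapiens) for inhibition, read by MTT assay, with a stated time of 72 h (on this read-out lower numbers stand for stronger inhibition and higher numbers for weaker inhibition), and compound 3 has the lowest number of the three. Compound 4 `Cc1cccc(N2CCN(C3=CC(=O)c4ccccc4C3=O)CC2)c1` has not been measured yet. It shares the core of compound 1 and carries 3-methylphenyl in place of 2-chlorophenyl on an amine nitrogen in a ring.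

Two measured steps arrive at the low number of compound 3, and both are modest: a 3.4-fold lower number from compound 1 to compound 3 (0.53 log units; beyond the scatter) and a 2.9-fold lower number from compound 2 to compound 3 (0.46 log units; beyond the scatter). The remaining step stays within the scatter: a 1.2-fold lower number from compound 1 to compound 2 (0.08 log units; within the scatter). Among these three compounds, only the one carrying 2-chlorophenyl stands apart, and compound 4 gives that group up. Going by the values given here, no measured compound carries 3-methylphenyl, so the effect of the methyl group remains unknown. Compound 4 is therefore expected to return towards the values of compound 1 and compound 2, which means a higher number. The expected modest size is a 2.6-fold higher number from compound 3 to compound 4 (0.41 log units; beyond the scatter), an estimate similar in scale to the measured steps above. The estimate for compound 4 is 7500 nM, with an expected range from 3500 nM to 15000 nM.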

Compound 4, half-maximal inhibitory concentration: 7400 nM
For compound 4 the middle estimate is 1.0-fold (0.01 log units) above the measured one, within the range that was stated.
By their numbers in this assay, from the lowest: compound 3; then compounds 4, 2 and 1 (each within the scatter of the next).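

In this assay, the change to 3-methylphenyl in place of 2-chlorophenyl on the amine nitrogen gives up the low number of compound 3 (a 2.6-fold higher number from compound 3 to compound 4 (0.41 log units; beyond the scatter)), and it alters both the substituent and where that substituent sits on the phenyl ring. The other two steps separate these effects in part: methyl in place of chloro leaves the number within the scatter (a 1.1-fold lower number from compound 2 to compound 4 (0.05 log units; within the scatter)), as does methyl in place of hydrogen (a 1.3-fold lower number from compound 1 to compound 4 (0.13 log units; within the scatter)), so phenyl, 3-chlorophenyl and 3-methylphenyl cannot be told apart here, and among these four compounds only 2-chlorophenyl stands apart. Nothing available explains why this one group differs from the other three.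

The compounds shown leave open whether the low number of compound 3 depends on chlorine itself or on any group at that ring position, a question that 2-methylphenyl would address directly. They also leave open how groups of another kind, such as methoxy or an amine on the phenyl ring, would behave on the same shared core.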